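Lactam-capped chalcone series: nitro for difluoro swap

The source may report more compounds than this note shows. Statements on the series, on what has been measured and on what is new or still open speak of the compounds shown alone.

Three compounds have been run in a functional assay on MCF7 cells (Homo sapiens) for antiproliferative activity, read by MTT assay, with a stated time of 72 h; a higher number here means a weaker inhibitor, a lower number a stronger inhibitor. Compound 1 `Cc1ccc(C(C)C)c(OCCSC(=S)N[C@H]2CCOC2=O)c1` returned only a limit of the assay, > 64000 nM. Compound 3 `O=C1OCC[C@@H]1NC(=S)SCCOc1ccccc1[N+](=O)[O-]` likewise gave only a limit, > 64000 nM. Compound 2 `O=C(COc1ccc(C(=O)/C=C/c2ccc(F)c(F)c2)cc1)N[C@H]1CCOC1=O` also sits at a limit, > 64000 nM, so no number is known for it; it stands at the limit of > 64000 nM in this assay, at which 3 of the 3 values shown sit, together with the other two, and nothing separates the three within what has been measured.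

Compound 4 `O=C(COc1ccc(C(=O)/C=C/c2cccc([N+](=O)[O-])c2)cc1)N[C@H]1CCOC1=O` is the next member: 3-nitrophenyl in place of 3,4-difluorophenyl on a double-bonded chain carbon bound to a double-bonded chain carbon. Among the compounds with values here, no measured step between two numbered compounds exists in this set, so the size of the change from compound 2 to compound 4 in this assay can only be guessed. Given that compound 2 gives > 64000 nM, the expectation for compound 4 is that it again lands at or near the limit of this assay, with no step beyond the scatter. The expected step that the limit leaves unreadable from compound 2 to compound 4 is taken as essentially flat. Compound 4 is estimated at 70000 nM, with a range from 20000 nM to 200000 nM.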

Compound 4, half-maximal inhibitory concentration: > 64000 nM
Compound 4 gave a limit, no number; the forecaster's own chance of this, stated with the estimate: 75%; the middle value does not contradict the limit.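

Compound 2 and compound 4 each return only a limit, so no step between them can be read: the limit of > 64000 nM in this assay, at which 4 of the 4 values shown sit.

The compounds shown leave open whether any member of this series gives a number in this assay, and whether 3-nitrophenyl and 3,4-difluorophenyl differ there at all.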